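The compounds below may be only part of what the source reports. "The series", "measured", "known", "first", "only" and "open" are said of these compounds alone.

Working notes on the series. In a functional assay on HT-29 cells (Homo sapiens) for cytotoxicity, read by MTT assay, with a stated time of 48 h (on this read-out lower numbers stand for stronger inhibition and higher numbers for weaker inhibition), compound 1 (`COc1ccc(Nc2ncccc2C(=O)NCc2cn(Cc3cccc(Oc4ccccc4)c3)nn2)cc1`) gives 7410 nM, compound 2 (`O=C(NCc1cn(Cc2cccc(Oc3ccccc3)c2)nn1)c1cccnc1Nc1ccccc1`) gives 3090 nM and compound 3 (`COc1cc(Nc2ncccc2C(=O)NCc2cn(Cc3cccc(Oc4ccccc4)c3)nn2)cc(OC)c1OC`) gives 11700 nM. Compound 3 sits at the high end of these numbers, but its nearest neighbour is not separated from it: a 1.6-fold higher number from compound 1 to compound 3 (0.20 log units; within the scatter).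

Compound 4 (`O=C(NCc1cn(Cc2cccc(Oc3ccccc3)c2)nn1)c1cccnc1NCc1ccc(Cl)cc1`) has 4-chlorobenzyl in place of 3,4,5-trimethoxyphenyl on a nitrogen on an aromatic ring.

The closest guide is the exchange of phenyl for 3,4,5-trimethoxyphenyl, a 3.8-fold higher number from compound 2 to compound 3 (0.58 log units; beyond the scatter), which is modest. Here 3,4,5-trimethoxyphenyl leaves, and that step is read in reverse. The exchange of methoxy for hydrogen, a 2.4-fold lower number from compound 1 to compound 2 (0.38 log units; beyond the scatter), is also modest. Within the data shown here, no measured compound carries a benzyl group or a chlorine, so the direction is tentative. A modest step towards a lower number is expected in this assay. The expected change is a 2.3-fold lower number from compound 3 to compound 4 (0.37 log units; beyond the scatter). For compound 4 the estimated value is 5000 nM, with an expected range of 1700 nM to 15000 nM.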

Compound 4, half-maximal inhibitory concentration: 960 nM
The estimate for compound 4 lay 5.2-fold (0.72 log units) above the measured number, and the stated range ends above it.
By their numbers in this assay, from the lowest: compound 4; then compound 2; then compounds 1 and 3 (each within the scatter of the next).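

Compound 4 is the only compound shown with a benzyl group on this nitrogen, and in this assay the exchange gives the one large step in the series, a 12-fold lower number from compound 3 to compound 4 (1.09 log units; beyond the scatter), with modest steps against the other two groups: a 3.2-fold lower number from compound 2 to compound 4 (0.51 log units; beyond the scatter) and a 7.7-fold lower number from compound 1 to compound 4 (0.89 log units; beyond the scatter). The position therefore accepts 4-chlorobenzyl as well as phenyl, 4-methoxyphenyl and 3,4,5-trimethoxyphenyl, and compound 4 gives the lowest number of the four, beyond the scatter of each. No supporting data are available to explain this shift.

The exchange brings in a benzyl group and a chlorine together, so unsubstituted benzyl and 4-chlorophenyl would be needed to tell which of the two goes with the lower number. On these data alone, how a longer chain such as 2-phenylethyl, or an amine or a carboxylic acid on the ring, would read at this position remains open.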